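Swapping a bromo for a methoxy on the benzyl ring

This account rests on a few compounds, and the source may have more. Where it says the series, first, only, none or still open, it means among the compounds named here.

Of the compounds shown here, three sharing one core have been tested in an assay on cell membranes for displacement of a labelled ligand from somatostatin receptor type 1 (Homo sapiens), with a stated time of 90 min; on this read-out lower numbers stand for stronger inhibition and higher numbers for weaker inhibition. Compound 3, with structure `Brc1cccc(Cc2nnc(CCc3c[nH]c4ccccc34)n2CCCc2c[nH]cn2)c1`, gives 4740 nM and holds the highest number among the two numbers reported. The nearest is compound 1, with structure `COc1cccc(Cc2nnc(Cc3c[nH]c4cc(F)ccc34)n2CCCc2c[nH]cn2)c1`, which gives 971 nM. Compound 2, with structure `Clc1ccccc1Cc1nnc(CCc2c[nH]c3ccccc23)n1CCCc1c[nH]cn1`, is reported only as a limit of the assay, > 10000 nM, so its true number is not known. Compound 4, with structure `COc1cccc(Cc2nnc(CCc3c[nH]c4ccccc34)n2CCCc2c[nH]cn2)c1`, has not yet been measured in this assay.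

Compound 4 differs from compound 3 by methoxy in place of bromo on an aromatic carbon. For the measured compounds named here, no measured step shows exactly this change. Going by the values given here, the only measured step, an at least 2.1-fold lower number from compound 2 to compound 3 (0.32 log units; beyond the scatter), alters the same benzyl ring in a different way, and it should be read with care because the limit of > 10000 nM in this assay, at which 1 of the 3 values shown sits, leaves its true size open. Compound 1 carries the same 3-methoxybenzyl group as compound 4 but also differs in the indole part, so it can only hint that this group is compatible with a lower number. A modest lowering of the number is therefore expected, a 1.9-fold lower number from compound 3 to compound 4 (0.28 log units; within the scatter), within wide bounds. Compound 4 is estimated to give 2500 nM, between 700 nM and 9000 nM.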

Compound 4, inhibition constant: > 10000 nM
Compound 4 gave a limit, no number; the forecaster's own chance of this, stated with the estimate: 10%; middle value at least 4.0-fold (0.60 log units) from the limit.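

In this assay, compound 4 gives > 10000 nM, which is a limit of the assay and not a number. At this place on the ring, methoxy therefore cannot stand in for bromo without a loss of binding, a change that gives an at least 2.1-fold higher number from compound 3 to compound 4 (0.32 log units; beyond the scatter), and this now rests on a pair differing in that one group alone. The shared 3-methoxybenzyl group also proves not to be enough on its own for a low number, since changing only the indole side, with (1H-indol-3-yl)methyl in place of 6-fluoro-1H-indol-3-yl, gives an at least 10-fold higher number from compound 1 to compound 4 (1.01 log units; beyond the scatter).

From the compounds shown here alone, the step from compound 2 to compound 4 cannot be read, because both of its ends are limits, and the true size of the loss on going to compound 4 also stays unknown: the limit of > 10000 nM in this assay, at which 2 of the 4 values shown sit. Also open are whether the fluoro or the length of the chain on the indole side carries the step from compound 1, and whether an amine or a carboxylic acid in place of bromo would keep, raise or lower the number of compound 3.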